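Acetoxy in place of formyl on the aromatic ring

The source may hold more compounds than are shown below. What is called first, only, known or untested is meant among the compounds shown, and "the series" means these compounds.

Compound 3 `CC1(C)C=C(n2ccccc2=O)c2cc(C=O)ccc2O1` gives 6.91 in a functional assay (aorta) with Rattus norvegicus as the target (a lower number here means a less potent compound, a higher number a more potent compound, by a factor of ten per unit of this negative logarithm), the highest of the three numbers measured; compound 2 `CC1(C)C=C(n2ccccc2=O)c2cc(C(=O)c3ccccc3)ccc2O1` gives 6.61 and compound 1 `CC1(C)C=C(n2ccccc2=O)c2ccccc2O1` gives 5.43. The steps of a number 1.18 log units higher from compound 1 to compound 2 (beyond the scatter) and a number 1.48 log units higher from compound 1 to compound 3 (beyond the scatter) are both large, while the step of a number 0.30 log units higher from compound 2 to compound 3 (within the scatter) is within the scatter. Compound 4 `CC(=O)Oc1ccc2c(c1)C(n1ccccc1=O)=CC(C)(C)O2` differs from compound 3 by acetoxy in place of formyl on an aromatic carbon. Within the data shown here, no measured step covers acetoxy; the only guidance is that both carbonyl-bearing groups in place of hydrogen raised the number sharply. Compound 4 is therefore expected to stay well above compound 1, but a modest loss against compound 3 is estimated, a number 0.61 log units lower from compound 3 to compound 4 (beyond the scatter). The estimate for compound 4 is 6.3, in the range 5.6 to 7.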

Compound 4, logarithm of the reciprocal of the active concentration, log(1/C): 5.6
The estimate for compound 4 lay 0.70 log units above the measured number, and the stated range covers the measured number.
By their numbers in this assay, from the lowest: compounds 1 and 4 (each within the scatter of the next); then compounds 2 and 3 (each within the scatter of the next).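

Acetoxy in place of hydrogen on this aromatic carbon gives a number 0.17 log units higher from compound 1 to compound 4 (within the scatter) in this assay and so does not share the large rise seen with formyl and benzoyl. Against those two groups, the steps of a number 1.31 log units lower from compound 3 to compound 4 (beyond the scatter) and a number 1.01 log units lower from compound 2 to compound 4 (beyond the scatter) are both large, which shows that a carbonyl in the entering group is not enough at this place. No supporting data bear on why acetoxy differs from formyl and benzoyl here.

The compounds shown leave open how acetyl, a nitrile or a carboxylic acid would read at this aromatic carbon. They also leave open whether the rise requires a carbonyl carbon bonded directly to the ring.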